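Chloro for Fluoro on the Core of Compound 3

The source may hold more compounds than are shown below. What is called first, only, known or untested is meant among the compounds shown, and "the series" means these compounds.

Compound 3 `O=C1C(=O)N(CCCCCn2cc(COc3cc(=O)oc4ccccc34)nn2)c2ccc(F)cc21` stands highest of the three compounds measured in a functional assay on HCT-116 cells (Homo sapiens) for inhibition, read by sulforhodamine B assay, with a stated time of 48 h, tested at 50 uM (on this read-out higher numbers stand for more inhibition of growth at the one concentration tested and lower numbers for less inhibition of growth), where compound 3 gives 59%. Compound 1 `COc1ccc2c(c1)C(=O)C(=O)N2CCCCCn1cc(COc2cc(=O)oc3ccccc23)nn1` gives 25% and compound 2 `O=C1C(=O)N(CCCCCn2cc(COc3cc(=O)oc4ccccc34)nn2)c2ccc([N+](=O)[O-])cc21` gives 29%. The steps of a number 34 percentage points higher from compound 1 to compound 3 (beyond the scatter) and a number 30 percentage points higher from compound 2 to compound 3 (beyond the scatter) are both large, whereas the step of a number 4 percentage points higher from compound 1 to compound 2 (within the scatter) is the only small one. Compound 4 `O=C1C(=O)N(CCCCCn2cc(COc3cc(=O)oc4ccccc34)nn2)c2ccc(Cl)cc21` differs from compound 3 by chloro in place of fluoro on an aromatic carbon. Going by the values given here, no measured step exchanges one halogen for another, so the two large steps show only that this position answers strongly to what sits on it. A change as large as those two is not expected here; compound 4 is expected to give 52% (range 30% to 72%). That estimate means an expected step of a number 7 percentage points lower from compound 3 to compound 4 (within the scatter), within the scatter.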

Compound 4, percent growth inhibition at one concentration: 52%
For compound 4 middle estimate and measured number coincide at the digits printed; measured number inside the range.
By their numbers in this assay, from the lowest: compounds 1 and 2 (each within the scatter of the next); then compounds 4 and 3 (each within the scatter of the next).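

Chloro in place of fluoro is the first exchange of one halogen for another at this position, and in this assay it gives a number 7 percentage points lower from compound 3 to compound 4 (within the scatter). The chloro compound also keeps clear of the other two groups, with a number 23 percentage points higher from compound 2 to compound 4 (beyond the scatter) and a number 27 percentage points higher from compound 1 to compound 4 (beyond the scatter), so the higher number at this position is not confined to fluoro. No evidence available here bears on why this is so. Going by these compounds, it remains open whether bromo or an amine on the same aromatic carbon would match the two halogens, and how a longer linking chain would affect the number.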